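A new phenyl group on compound 2

The compounds below may be only part of what the source reports. "The series", "measured", "known", "first", "only" and "open" are said of these compounds alone.

In a functional assay on PC-9ER cells (Homo sapiens) for antiproliferative activity, read by CellTiter-Glo, with a stated time of 72 h (on this read-out higher numbers stand for weaker inhibition and lower numbers for stronger inhibition), compound 1 `O=C(Nc1cccc(-c2cnc3c(NC(=O)c4cc(Cl)cc(Cl)c4)nccn23)c1)c1ccc(Cl)c(C(F)(F)F)c1` gives 3630 nM and compound 2 `O=C(Nc1cccc(-c2cnc3c(NC(=O)c4cc(Cl)cc(Cl)c4)nccn23)c1)Nc1ccc(F)cc1F` gives 2560 nM, so the two stand within the scatter of each other. Compound 3 `O=C(Nc1cccc(-c2cnc3c(NC(=O)c4cc(Cl)cc(Cl)c4)nccn23)c1)Nc1ccc(Cl)c(C(F)(F)F)c1` carries 4-chloro-3-(trifluoromethyl)phenyl in place of 2,4-difluorophenyl on an amide-type nitrogen. Within the data shown here, one measured step bears on this change, as it also involves both of these groups: a 1.4-fold lower number from compound 1 to compound 2 (0.15 log units; within the scatter). That step is small, so no change beyond the scatter is expected in this assay, and the estimated step is a 1.2-fold lower number from compound 2 to compound 3 (0.07 log units; within the scatter). For compound 3 the estimated value is 2200 nM, with a range of 700 nM to 6500 nM.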

Compound 3, half-maximal inhibitory concentration: 8010 nM
The estimate for compound 3 lay 3.6-fold (0.56 log units) below the measured number, outside the stated range (above it).
By their numbers in this assay, from the lowest: compounds 2 and 1 (each within the scatter of the next); then compound 3.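

In this assay, the group on the amide-type nitrogen matters: the assay shows a 3.1-fold higher number from compound 2 to compound 3 (0.50 log units; beyond the scatter) when 4-chloro-3-(trifluoromethyl)phenyl replaces 2,4-difluorophenyl. With that ring kept, it shows a 2.2-fold higher number from compound 1 to compound 3 (0.34 log units; beyond the scatter) when (4-chloro-3-(trifluoromethyl)phenyl)amino replaces 4-chloro-3-(trifluoromethyl)phenyl on the carbonyl carbon, so each single change moves the number, although the earlier pair, differing in both respects, stood within the scatter. No evidence at hand explains either shift.

Still open, as far as these compounds go, is how a plain phenyl or a pyridyl group on the amide-type nitrogen would read in this assay, and whether any such group would bring the number below those seen here.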